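The compounds below may be only part of what the source reports. "The series", "measured", "known", "first", "only" and "open" are said of these compounds alone.

Measured so far:
Compound 1 `CCO/N=C/Nc1cc(Cl)c(SCC)c(Cl)c1`: 4.6
Compound 2 `C#CCO/N=C/Nc1cc(Cl)c(CC#C)c(Cl)c1`: 3.3

Both numbers come from a physicochemical assay for lipophilicity, measured as octanol-water partition; a higher number here means a more lipophilic compound, a lower number a more polar compound. In this assay compound 1 gives 4.6 and compound 2 gives 3.3, so compound 2 holds the lower of the two values, and the gap between them is wider than the usual scatter of the measurement. The two compounds differ in more than one place, so nothing more can be read from that gap than the two values themselves.

Compound 3 `C#CCc1c(Cl)cc(N/C=N/OC/C=C\Cl)cc1Cl` has not yet been measured in this assay. It is built from compound 2 by a single change: 2-chloroethenyl in place of ethynyl on a saturated chain carbon bound to an oxygen on an unsaturated carbon. Among the measured compounds shown here, no measured pair shows this exact change, so its effect has to be expected rather than read off. The expectation is a moderate rise in this assay, beyond the scatter, since a group with one more heavy atom, including a chlorine, enters in place of the ethynyl. The expected step from compound 2 to compound 3 is a number 0.70 log units higher from compound 2 to compound 3 (beyond the scatter). Compound 3 is therefore estimated at 4, with a likely range from 3.6 to 4.5.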

Compound 3, partition coefficient: 3.9
Beside the measured number, compound 3's estimate is 0.10 log units above it, and the stated range covers the measured number.
By their numbers in this assay, from the lowest: compound 2; then compound 3; then compound 1.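

In this assay the result of putting 2-chloroethenyl in place of ethynyl, on a saturated chain carbon bound to an oxygen on an unsaturated carbon, is a number 0.60 log units higher from compound 2 to compound 3 (beyond the scatter) and so the number at this position does respond to this change. Among the compounds shown here, this is the first pair here that differs in one place, which means that a shift can now be tied to a single exchange of groups instead of to several differences at once. Nothing measured here accounts for the size or direction of that shift, so the step stands as an observation without an explanation.

A single pair says nothing about whether the same exchange would give a similar step elsewhere, for instance at the other propargyl group of compound 2, or on a different core. Also open, on these data alone, is how the number would move at this position with other groups in place of ethynyl, such as a longer saturated chain, an amine or a carboxylic acid.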